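From an Ethyl Amide to a Free Carboxylic Acid

The compounds below may be only part of what the source reports. "The series", "measured", "known", "first", "only" and "open" are said of these compounds alone.

Of the compounds shown here, two in this set have been measured in an assay on isolated protein for inhibition of protein kinase C zeta type (Homo sapiens), with stated times of 1 h and 2.5 min, tested at 30 uM; on this read-out lower numbers stand for less inhibition and higher numbers for more inhibition at the one concentration tested (going by the name of the read-out). Compound 1, `COc1ccc(-c2csc(N)c2C(=O)OCc2ccc(C#N)cc2)cc1OC`, gives 10% in this assay. Compound 2, `CCNC(=O)c1c(-c2ccc(OC)c(OC)c2)csc1N`, gives 50% in this assay. Among the two numbers, compound 2 stands highest, and its nearest neighbour is compound 1, whose reading lies lower by a gap that is beyond the usual scatter of repeated measurements, so compound 2 gives the higher inhibition of the pair in this assay at the single concentration tested.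

Compound 3, `COc1ccc(-c2csc(N)c2C(=O)O)cc1OC`, has not yet been measured. It differs from compound 2 in one place: hydroxy in place of ethylamino on a carbonyl carbon. Among the measured compounds shown here, no pair of measured compounds shows this particular change, so there is no measured step to lean on for its size or direction. Given that, the account here expects a downward step beyond the scatter, with the expected step written as a number 30 percentage points lower from compound 2 to compound 3 (beyond the scatter). Compound 3 is therefore estimated to give 20% in this assay, with a range from 0% to 45%.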

Compound 3, a percentage reported as inhibition, at one concentration (the size of the read-out at that concentration, not a potency): 65%
Estimate against measurement, compound 3: 45 percentage points below; the whole stated range lies below it.
By their numbers in this assay, from the lowest: compound 1; then compound 2; then compound 3.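

At this carbonyl carbon the carboxy group does not cost inhibition. In this assay, hydroxy in place of ethylamino gives a number 15 percentage points higher from compound 2 to compound 3 (beyond the scatter), so among the compounds shown neither the ethylamino group nor its carbon atoms are needed for the reading. The same position also carries the largest step seen so far: hydrogen in place of 4-cyanobenzyl on an oxygen next to a carbonyl group gives a number 55 percentage points higher from compound 1 to compound 3 (beyond the scatter), which places the 4-cyanobenzyl ester well apart from the carboxy compound, something the earlier pair could not show as a step. Nothing available explains why either change moves the reading as it does.

The compounds shown leave open whether a small ester such as the methyl ester, or a primary amide, would read nearer to compound 3 or nearer to compound 1, and so whether the size of the group on this carbonyl carbon tracks the reading at all. They also leave open whether the methoxy groups or the amine on the shared core take part in the effect, and how these single-concentration steps would translate into potency.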